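A few compounds are considered here, and "the series" means these few. Any claim that something is new, unique, unknown or untested is made for them only; others in the source may bear on it.

Compound 1 `C=C1C[C@](C)(CO)OC1=O`: 26700 nM
Compound 2 `C=C1C[C@H]([C@H](C)O)OC1=O`: 17300 nM
Compound 3 `C=C1C[C@H]([C@H](O)CCC)OC1=O`: 18500 nM

All three were tested in a functional assay on L1210 cells (Mus musculus) for cytotoxicity; on this read-out higher numbers stand for weaker inhibition and lower numbers for stronger inhibition. Compound 3 gives the second highest of the three numbers; its nearest neighbour is compound 2 and its furthest is compound 1, yet both gaps lie within the scatter of repeated measurements, so the three cannot be ranked. Compound 4 `C=C1C[C@H](CO)OC1=O` has not yet been measured in this assay. It differs from compound 3 in one place: hydrogen in place of propyl on a saturated chain carbon bound to an oxygen on a saturated carbon and a saturated ring carbon. Going by the values given here, no measured pair differs in only one place, so no measured step guides this change; with all three numbers sitting close together, a step no larger than the scatter is expected in this assay, in no particular direction. Compound 4 is estimated at 22000 nM, with a range from 9000 nM to 55000 nM. The expected step is a 1.2-fold higher number from compound 3 to compound 4 (0.08 log units; within the scatter).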

Compound 4, half-maximal inhibitory concentration in the L1210 assay: 27200 nM
Estimate against measurement, compound 4: 1.2-fold (0.09 log units) below, and the stated range covers the measured number.
By their numbers in the L1210 assay, from the lowest: compounds 2, 3, 1 and 4 (each within the scatter of the next).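

Hydrogen in place of propyl or methyl on this carbon gives no readable difference in the L1210 assay: a 1.5-fold higher number from compound 3 to compound 4 (0.17 log units; within the scatter), and a 1.6-fold higher number from compound 2 to compound 4 (0.20 log units; within the scatter). In a physicochemical assay for lipophilicity (on this read-out lower numbers stand for lower lipophilicity and higher numbers for higher lipophilicity), compound 3 gives 1.59 and compound 4 gives 0.15, a wide gap on that read-out. So for this pair, a large difference in lipophilicity comes with no readable difference in the L1210 assay: the measured partition coefficient of compound 3, 1.59, and of compound 4, 0.15, a number 1.44 log units lower (beyond the scatter)

Still open, on these data alone, is whether an amine, a carboxylic acid or a longer chain on this carbon would give a number in the L1210 assay beyond the scatter.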